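A few compounds are considered here, and "the series" means these few. Any claim that something is new, unique, unknown or untested is made for them only; others in the source may bear on it.

Of the compounds shown here, two bearing the same core have been measured in a functional assay on cells for antagonist activity at taste receptor type 2 member 8 (Homo sapiens), read by FLIPR and calcium flux, with a stated time of 100 s; a higher number here means a weaker inhibitor, a lower number a stronger inhibitor. Compound 1 `Cc1noc(C)c1Cn1cc(NC(=O)c2ccc3[nH]ccc3c2)cn1` gives 300 nM in this assay, and compound 2 `Cc1noc(C)c1Cn1cc(N2C(=O)CN(Cc3ccccc3O)C2=O)cn1` gives 100 nM, the lower of the two numbers, a gap described as beyond the scatter. Compound 3 `CNC(=O)c1cccc(CN2CC(=O)N(c3cnn(Cc4c(C)noc4C)c3)C2=O)c1` differs from compound 2 in one place: 3-(methylcarbamoyl)phenyl in place of 2-hydroxyphenyl on a saturated chain carbon bound to an amide-type nitrogen in a ring. For the measured compounds named here, no measured pair shows this exact change, so only a guarded expectation can be drawn. From compound 2 to compound 3 a step of a 1.5-fold higher number from compound 2 to compound 3 (0.18 log units; within the scatter) is expected, in no direction that clearly exceeds the scatter. Compound 3 is therefore estimated at 150 nM, within a range from 50 nM to 500 nM.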

Compound 3, half-maximal inhibitory concentration: 100 nM
Estimate against measurement, compound 3: 1.5-fold (0.18 log units) above; measured number inside the range.
By their numbers in this assay, from the lowest: compounds 2 and 3 (each within the scatter of the next); then compound 1.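

In this assay, exchanging the 2-hydroxyphenyl group for the 3-(methylcarbamoyl)phenyl group gives no change at the digits printed from compound 2 to compound 3 (within the scatter). This position therefore accepts a larger group with a different substituent on its phenyl ring, and the 2-hydroxyl is not needed to keep this level of inhibition. As far as these compounds go, whether a phenyl ring carrying an amine or a carboxylic acid, or a longer chain leading to the ring, would also hold this number stays open. Nothing at hand explains why these two groups read alike.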